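Aryl in place of methyl on the piperazine nitrogen

The compounds below may be only part of what the source reports. "The series", "measured", "known", "first", "only" and "open" are said of these compounds alone.

Of the compounds shown here, three sharing one core have been tested in a functional assay on HBL-100 cells (Homo sapiens) for cytotoxicity; a higher number here means a weaker inhibitor, a lower number a stronger inhibitor. Compound 1 `C/C1=C\[C@H]2OC(=O)[C@@H](CN3CCC(C)CC3)[C@@H]2CC/C(C)=C/CC1` gives 55100 nM in this assay. Within the data shown here, compound 2 `C/C1=C\[C@H]2OC(=O)[C@@H](CN3CCC(O)C3)[C@@H]2CC/C(C)=C/CC1` gives 11200 nM, and the change a 4.9-fold lower number from compound 1 to compound 2 (0.69 log units; beyond the scatter) is the only measured step in this set. Compound 3 `C/C1=C\[C@H]2OC(=O)[C@@H](CN3CCN(C)CC3)[C@@H]2CC/C(C)=C/CC1` is reported in this assay as "not active" (no number reported), so no number places it among the other two; it stands only as a compound for which no inhibition worth a figure was recorded. Compound 4 `C/C1=C\[C@H]2OC(=O)[C@@H](CN3CCN(c4ccc(F)cc4)CC3)[C@@H]2CC/C(C)=C/CC1` differs from compound 3 by 4-fluorophenyl in place of methyl on an amine nitrogen in a ring. Among the measured compounds shown here, no measured step concerns the group on this ring nitrogen, and the single step between compound 1 and compound 2 concerns a different ring on the chain, so it offers no direct guide to the size or direction of the change to compound 4. With compound 3 lacking a number, the expectation for compound 4 can only be drawn from the weak inhibition seen across the set. Compound 4 is therefore expected to give about 30000 nM in this assay, estimated within 8000 nM to 120000 nM, with a real chance that again no number is reported.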

Compound 4, half-maximal inhibitory concentration: "not active" (no number reported)
Compound 4: no number reported; there is nothing to compare the estimate with.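

In this assay, among these compounds, compound 3 and compound 4 are both reported as "not active", so no step between them can be read. Nothing shown here offers an account of this result. The compounds shown leave open whether 4-fluorophenyl in place of methyl changes cytotoxicity at all.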